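A few compounds are considered here, and "the series" means these few. Any claim that something is new, unique, unknown or untested is made for them only; others in the source may bear on it.

Compound 1, `O=C(CCCCCc1ccccc1)c1nc2cnccc2o1`, in an assay on HEK-293T cells for inhibition of diacylglycerol lipase-alpha (Homo sapiens), read by colorimetric assay (a higher number here means a weaker inhibitor, a lower number a stronger inhibitor), gives 204 nM.
Compound 2, `O=C(CCCCCc1ccccc1)c1nc2cccc(Br)c2o1`, in this assay reaches only a limit, > 10000 nM.
Compound 3, `O=C(CCCCCCc1ccccc1)c1nc(C(=O)C(F)(F)F)co1`, in this assay gives 123 nM.

All three carry a long phenyl-ended chain joined through a carbonyl to a five-membered aromatic core; they differ in that core and in what sits on it. Of the two numbers actually measured, compound 3 has the lowest, but its gap to compound 1 lies within the scatter, so the two cannot be set apart by these data. Compound 2 stands at a limit of the assay rather than at a number, as recorded by the limit of > 10000 nM in this assay, at which 1 of the 3 values shown sits.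

Compound 4, `O=C(CCCCCCc1ccccc1)c1nc(Cl)co1`, is the next compound and differs from compound 3 in a single place: chloro in place of (trifluoromethyl)carbonyl on an aromatic carbon. Among the compounds with values here, no measured pair shows this change, so no step can be read off from the data, and the size of the change has to be guessed. The expectation is a weaker inhibitor, with the step estimated as a 12-fold higher number from compound 3 to compound 4 (1.09 log units; beyond the scatter), which would lie beyond the scatter. Compound 4 is therefore expected to give about 1500 nM, most likely between 300 nM and 8000 nM, with a real chance that only a limit is reported.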

Compound 4, half-maximal inhibitory concentration: 2400 nM
The estimate for compound 4 lay 1.6-fold (0.20 log units) below the measured number; low and high end bracket the measured number.
By their numbers in this assay, from the lowest: compounds 3 and 1 (each within the scatter of the next); then compound 4. At a limit, above all of these: compound 2.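

Within the data shown here, replacing (trifluoromethyl)carbonyl with chloro gives the first direct reading at this position, on an aromatic carbon next to the ring nitrogen, with the phenyl-ended chain left unchanged: in this assay the change is a 20-fold higher number from compound 3 to compound 4 (1.29 log units; beyond the scatter) and lies well outside normal assay variation. The group at this position therefore matters a great deal, although compound 4 still gives a measured 2400 nM and not a limit, so inhibition is weakened but still measurable with chloro in place. The pair swaps a group of 6 heavy atoms for a single chlorine atom, and nothing measured here separates the part played by the carbonyl from that of the three fluorines or identifies what lies behind the step.

A simple acetyl group, a methyl ester, an amide or a nitrile at this position would show how much of the effect follows the carbonyl and how much needs the trifluoromethyl. Going by these compounds, it also remains open whether a step of this size would recur with a shorter chain or on the core of compound 1.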